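The source may hold more compounds than are shown below. What is called first, only, known or untested is meant among the compounds shown, and "the series" means these compounds.

Compound 1 `O=C(CCCCCCc1ccccc1)c1nncs1`, compound 2 `O=C(CCCCCCc1ccccc1)c1nnn[nH]1` and compound 3 `CN(C)C(=O)c1coc(C(=O)CCCCCCc2ccccc2)n1` share one scaffold, a phenyl-capped chain joined through a carbonyl to a small aromatic ring, and differ only in that ring. In an assay on HEK-293T cells for inhibition of diacylglycerol lipase-alpha (Homo sapiens), read by colorimetric assay (a higher number here means a weaker inhibitor, a lower number a stronger inhibitor), compound 1 gives only the limit > 10000 nM, not a number, sitting at the limit of > 10000 nM in this assay, at which 1 of the 3 values shown sits. Compound 2 likewise gives in this assay the limit > 10000 nM; > 10000 nM (2 entries) in two measurements. Within the data shown here, compound 3 is the one compound with a number: in this assay compound 3 gives 3390 nM. Compound 4 `O=C(CCCCCCc1ccccc1)c1nc(-c2ccncc2)co1` differs from compound 3 in one place: pyridin-4-yl in place of dimethylcarbamoyl on an aromatic carbon. Among the measured compounds shown here, no measured pair shows such a change, so its size is unknown; a small shift in either direction, or none beyond the scatter, is expected. Compound 4 is estimated at 2500 nM, with a range from 600 nM to 10000 nM. That estimate means a step of a 1.4-fold lower number from compound 3 to compound 4 (0.13 log units; within the scatter) is expected.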

Compound 4, half-maximal inhibitory concentration: > 10000 nM
Compound 4: a limit, no number; the forecaster's own chance of this, stated with the estimate: 20%; middle value at least 4.0-fold (0.60 log units) from the limit.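

Replacing dimethylcarbamoyl with pyridin-4-yl on the aromatic carbon next to the ring nitrogen gives, in this assay, an at least 2.9-fold higher number from compound 3 to compound 4 (0.46 log units; beyond the scatter), so activity at this position depends on the group it carries. The result for compound 4 is a limit, not a number, so the step has only a lower bound, and compound 4 joins the compounds that give no number: the limit of > 10000 nM in this assay, at which 2 of the 4 values shown sit.

Still open, from the compounds shown here alone, is how a carboxylic acid, a phenyl ring or a primary amide would behave at this position. Also open, going by these compounds, is whether a shorter or longer chain would change the value of compound 3.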